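The compounds below may be only part of what the source reports. "The series", "measured", "known", "first", "only" and "open" are said of these compounds alone.

Measured so far in a functional assay on SMMC-7721 cells (Homo sapiens) for antiproliferative activity, read by CCK-8 assay, with a stated time of 48 h; on this read-out lower numbers stand for stronger inhibition and higher numbers for weaker inhibition:
compound 1, `CCSc1n[nH]c(-n2[se]c3ccccc3c2=O)n1`, where compound 1 gives 10000 nM
compound 2, `CC(C)CSc1n[nH]c(-n2[se]c3ccccc3c2=O)n1`, where compound 2 gives 35000 nM
compound 3, `Cc1ccccc1CSc1n[nH]c(-n2[se]c3ccccc3c2=O)n1`, where compound 3 gives 36200 nM

Compound 3 carries the highest number of the three. Against compound 2 the difference is a 1.0-fold higher number from compound 2 to compound 3 (0.01 log units; within the scatter); against compound 1 it is a 3.6-fold higher number from compound 1 to compound 3 (0.56 log units; beyond the scatter). The remaining step, a 3.5-fold higher number from compound 1 to compound 2 (0.54 log units; beyond the scatter), runs the same way: both larger groups on the saturated chain carbon bound to a sulfur give higher numbers than methyl, while isopropyl and 2-methylbenzyl sit together within the scatter.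

Compound 4, `Cc1ccc(CSc2n[nH]c(-n3[se]c4ccccc4c3=O)n2)cc1`, has not yet been measured. Its change from compound 3 is 4-methylphenyl in place of 2-methylphenyl on a saturated chain carbon bound to a sulfur. Among the compounds with values here, no measured step rearranges a group in this way, so none bears on it directly; the only guidance is that compound 2 and compound 3, with different groups in this place, sit within the scatter of each other, which suggests that the choice among such groups here matters little. In this assay compound 4 is therefore expected to land near compound 3, with the step of a 1.0-fold lower number from compound 3 to compound 4 (0.01 log units; within the scatter) expected to stay within the scatter. The estimate for compound 4 is 35000 nM, with a range from 15000 nM to 80000 nM.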

Compound 4, half-maximal inhibitory concentration: > 50000 nM
Compound 4 ended at the assay's limit (the forecaster's own chance of this, stated with the estimate: 10%); middle value at least 1.4-fold (0.15 log units) away from the limit.
By their numbers in this assay, from the lowest: compound 1; then compounds 2 and 3 (each within the scatter of the next). At a limit, above all of these: compound 4.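

In this assay compound 4 gives > 50000 nM, which is a limit of the assay and not a number: the limit of > 50000 nM in this assay, at which 1 of the 4 values shown sits. Within the data shown here, this is the first reading of a rearrangement at this place, with the same atoms joined differently, and it gives an at least 1.3-fold higher number from compound 3 to compound 4 (0.14 log units; that floor lies within the scatter); the change from isopropyl gives an at least 1.4-fold higher number from compound 2 to compound 4 (0.15 log units; that floor lies within the scatter), and since both floors lie within the scatter, neither step separates compound 4 from its neighbours, while the true size of each gap stays unknown. Against the methyl group the separation is clear, with an at least 5.0-fold higher number from compound 1 to compound 4 (0.69 log units; beyond the scatter), so compound 4 joins compound 2 and compound 3 in giving a higher number than compound 1, and no compound shown goes against this among the groups on the saturated chain carbon bound to a sulfur.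

On these data alone, how far compound 4 lies past the limit, and so how much the switch from 2-methylphenyl to 4-methylphenyl matters here, stays open. Also open, as far as these compounds go, is what an unsubstituted phenyl, a 4-methoxyphenyl or a carboxylic acid at this place would give, and whether any group here gives a lower number than compound 1.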